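A few compounds are considered here, and "the series" means these few. Any claim that something is new, unique, unknown or untested is made for them only; others in the source may bear on it.

Compound 1 `CN(Cc1ccc(S(C)(=O)=O)cc1)C1CCN(CCCc2c[nH]c3ccc(-n4cnnc4)cc23)CC1` gives 18 nM in an assay on CHO cells for displacement of a labelled ligand from 5-hydroxytryptamine receptor 1D (Homo sapiens); on this read-out higher numbers stand for weaker inhibition and lower numbers for stronger inhibition.
Compound 2 `CC(C)=CCN(C)C1CCN(CCCc2c[nH]c3ccc(-n4cnnc4)cc23)CC1` gives 0.5 nM.
Compound 3 `CNS(=O)(=O)Cc1ccc2[nH]cc(CCCN3CCC(N[C@H](C)c4ccccc4)CC3)c2c1` gives 43 nM.

Compound 2 gives the lowest number of the three; compound 1 sits above it by a 36-fold lower number from compound 1 to compound 2 (1.56 log units; beyond the scatter) reversed, and compound 3 sits higher still. Compound 4 `c1ccc2c(c1)CCC2NCC1CCN(CCCc2c[nH]c3ccc(-n4cnnc4)cc23)CC1` is not yet measured; it differs from compound 2 by ((2,3-dihydro-1H-inden-1-yl)amino)methyl in place of methyl(3-methylbut-2-en-1-yl)amino on a saturated ring carbon. For the measured compounds named here, the only step that touches the same place is a 36-fold lower number from compound 1 to compound 2 (1.56 log units; beyond the scatter), which was large and went toward lower numbers when the aromatic group left. Here an aromatic ring enters again, and the amine gains a hydrogen-bond donor. Going by the values given here, compound 3, with a secondary amine bearing an aryl-substituted carbon, gives a high number but differs in its core as well, so no step is drawn from it. Compound 4 is therefore expected to show a 20-fold higher number from compound 2 to compound 4 (1.30 log units; beyond the scatter), an estimated 10 nM with a range of 2 nM to 60 nM.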

Compound 4, half-maximal inhibitory concentration: 1.1 nM
The estimate for compound 4 lay 9.1-fold (0.96 log units) above the measured number, outside the stated range (below it).
By their numbers in this assay, from the lowest: compound 2; then compound 4; then compound 1; then compound 3.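

With ((2,3-dihydro-1H-inden-1-yl)amino)methyl on the saturated ring carbon, the result is only a 2.2-fold higher number from compound 2 to compound 4 (0.34 log units; beyond the scatter) and it stays far closer to compound 2 than the aromatic compound 1 does. An aromatic ring at this position therefore need not bring a large rise in the number, so the earlier step cannot be read as applying to every aromatic group. Nothing available explains this difference between the groups.

The change brings in both rings and a hydrogen-bond donor together, and these cannot be separated here. On these data alone, whether an unsubstituted benzyl group on the amine nitrogen would keep the number low remains open.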